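The source may report more compounds than this note shows. Statements on the series, on what has been measured and on what is new or still open speak of the compounds shown alone.

Measured so far:
compound 1 `COC(=O)/C=C/NC(=O)[C@@H](O)C(C)(C)CO`: -2%
compound 2 `CC(C)(C)OC(=O)/C=C/NC(=O)[C@@H](O)C(C)(C)CO`: -8%
to be measured: compound 3 `CC(C)(C)OC(=O)/C=C\NC(=O)[C@@H](O)C(C)(C)CO`

In an ADME assay on HEK293 cells (Homo sapiens) for inhibition, read by CellTiter-Glo, with a stated time of 96 h, tested at 100 uM (a higher number here means more inhibition at the concentration tested (going by the name of the read-out), a lower number less inhibition), compound 1 gives -2% and compound 2 gives -8%; compound 2 holds the lowest of the two numbers, with compound 1 nearest, both within the scatter of each other. Among the measured compounds shown here, the only measured step, a number 6 percentage points lower from compound 1 to compound 2 (within the scatter), concerns the ester group and says nothing directly about the double bond. Compound 3 differs from compound 2 only thus: the two compounds have the same atoms and bonds and differ only in configuration as drawn: 1 of 2 stereo elements differ; a double bond is drawn E in compound 2 and Z in compound 3. For the measured compounds named here, with no matching step and both known numbers near zero, no change beyond the scatter is expected, a number 3 percentage points higher from compound 2 to compound 3 (within the scatter). Compound 3 is estimated at -5%, between -20% and 10%.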

Compound 3, a percentage reported as inhibition, at one concentration (the size of the read-out at that concentration, not a potency): -11%
Estimate against measurement, compound 3: 6 percentage points above; low and high end bracket the measured number.
By their numbers in this assay, from the lowest: compounds 3, 2 and 1 (each within the scatter of the next).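

The double bond itself is now tested, whereas the earlier step touched only the ester: in this assay, going from E to Z gives a number 3 percentage points lower from compound 2 to compound 3 (within the scatter). With the tert-butyl ester in place, the geometry of this double bond therefore shows no change beyond the scatter. The comparison isolates this single element: the fact that compounds 2 and 3 differ only in the configuration as drawn.

On these data alone, whether the same holds for the Z double bond with the methyl ester remains open. Also open, as far as these compounds go, is what a carboxylic acid or a primary amide in place of the ester would give in this assay.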